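Swapping the Amide-Linked Heteroaryl Group and Clearance

This account rests on a few compounds, and the source may have more. Where it says the series, first, only, none or still open, it means among the compounds named here.

Of the compounds shown here, two that share one core have been tested in an ADME assay on cells (Hepatocyte, Rattus norvegicus) for metabolic stability; a lower number here means slower removal, a higher number faster removal of the compound. Compound 1 `Cc1ccc2[nH]c(C(=O)N[C@H]3CN(S(=O)(=O)c4ccccc4)C[C@@H]3C(=O)N[C@@H]3CCCNC3)cc2c1` gives 9 uL/min in this assay. Compound 2 `O=C(N[C@H]1CN(S(=O)(=O)c2ccccc2)C[C@@H]1C(=O)N[C@H]1CCCNC1)c1cc(C2CC2)n[nH]1` reaches only a limit of this assay, reported as < 1 uL/min, so its true number is not known. Because of the limit of < 1 uL/min in this assay, at which 1 of the 2 values shown sits, compound 2 stands at the slow end of what this assay can report, while compound 1 sits at a measurable number. Compound 3 `O=C(N[C@H]1CN(S(=O)(=O)c2ccccc2)C[C@@H]1C(=O)N[C@H]1CCCNC1)c1cc(-c2ccccc2Cl)on1` is not yet measured. It differs from compound 2 in one place: a group of 12 heavy atoms (9 carbon, 1 nitrogen, 1 oxygen, 1 chlorine; one five-membered aromatic ring with 2 hetero atoms, one six-membered aromatic ring of carbon only) in place of a group of 8 heavy atoms (6 carbon, 2 nitrogen; one three-membered non-aromatic ring of carbon only, one five-membered aromatic ring with 2 hetero atoms), on a carbonyl carbon. For the measured compounds named here, no measured pair shows this kind of change, so the direction is uncertain. The step from compound 2 to compound 3 in this assay is expected to be an at least 5.0-fold higher number from compound 2 to compound 3 (0.69 log units; beyond the scatter), towards faster removal, though a number close to the limit is also plausible. Compound 3 is estimated to give 5 uL/min, within a range of 1 uL/min to 25 uL/min.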

Compound 3, intrinsic clearance in a liver preparation (reported as CLH), per the amount of preparation that the assay uses: 8.3 uL/min
Beside the measured number, compound 3's estimate is 1.7-fold (0.22 log units) below it; the measured number falls inside the stated range.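

For the compounds shown here, this is the first pair differing in one place, so it gives the first direct reading of this position in this assay. Replacing 3-cyclopropyl-1H-pyrazol-5-yl on the carbonyl carbon with the larger chlorine-bearing group gives an at least 8.3-fold higher number from compound 2 to compound 3 (0.91 log units; beyond the scatter), so the number in this assay responds to what sits at this place. The true size of the step stays unknown because one end of it is not a number: the limit of < 1 uL/min in this assay, at which 1 of the 3 values shown sits.

One pair cannot tell which part of the change counts: the chlorine, the added six-membered aromatic ring, or the swap from 1 hydrogen-bond donor to 0. It also leaves open how the number would move with a fluorine or a methyl group in place of the chlorine, or with a morpholine on the carbonyl carbon.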